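From 4-Chlorophenyl to 4-Hydroxyphenyl: One More Step

The source may report more compounds than this note shows. Statements on the series, on what has been measured and on what is new or still open speak of the compounds shown alone.

Of the compounds shown here, two have numbers so far in a functional assay on K562 cells (Homo sapiens) for inhibition, read by trypan blue exclusion, with a stated time of 72 h; a higher number here means a weaker inhibitor, a lower number a stronger inhibitor. Compound 1 (`Cn1c(=O)c(S(=O)(=O)c2ccc(Cl)cc2Cl)cc2cnc(Nc3ccc4[nH]ccc4c3)nc21`) gives 1000 nM and compound 2 (`Cn1c(=O)c(S(=O)(=O)c2ccc(Cl)cc2)cc2cnc(Nc3ccc4[nH]ccc4c3)nc21`) gives 100 nM as the lower number of the pair, which makes compound 2 the stronger inhibitor of the two. Compound 3 (`Cn1c(=O)c(S(=O)(=O)c2ccc(O)cc2)cc2cnc(Nc3ccc4[nH]ccc4c3)nc21`) keeps the core of compound 2 and changes one group, described as hydroxy in place of chloro on an aromatic carbon in a swap of hydroxy in place of chloro on an aromatic carbon. Within the data shown here, the only measured step that bears on this is a different one, hydrogen in place of chloro on an aromatic carbon, which gave a 10-fold lower number from compound 1 to compound 2 (1.00 log units; beyond the scatter) and shows that a single edit on this part of the molecule can move the number clearly. Among the measured compounds shown here, that step involved a different chloro, and no hydroxy compound has a measured number yet, so it is only a loose guide. The expected result is a smaller shift towards a higher number, estimated as a 2.0-fold higher number from compound 2 to compound 3 (0.30 log units; within the scatter) in this assay and uncertain in direction. For compound 3 the estimate is 200 nM with 40 nM to 1000 nM as its expected range.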

Compound 3, half-maximal inhibitory concentration: 100 nM
Estimate against measurement, compound 3: 2.0-fold (0.30 log units) above; measured number inside the range.
By their numbers in this assay, from the lowest: compounds 2 and 3 (each within the scatter of the next); then compound 1.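

Replacing the chloro with hydroxy, on an aromatic carbon para to a large group, gives no change at the digits printed from compound 2 to compound 3 (within the scatter) in this assay, so compound 2 and compound 3 cannot be told apart in this assay. This is the first sign that this position can take a group other than chloro with no measurable loss, even though hydroxy brings one hydrogen-bond donor and one acceptor that chloro lacks, and the earlier compounds had shown only the removal of a chloro from elsewhere on the ring. Compound 3 also keeps the distance from compound 1 that compound 2 showed, with a 10-fold lower number from compound 1 to compound 3 (1.00 log units; beyond the scatter), and nothing at hand explains why chloro and hydroxy read alike here.

The compounds shown leave open how an amine, a methoxy group or a carboxylic acid in this same place would read in this assay, and whether a plain phenyl, with only hydrogen there, would stand level with compound 2 and compound 3. They also leave open whether hydroxy would read the same on a ring that keeps the second chloro of compound 1.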